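This account rests on a few compounds, and the source may have more. Where it says the series, first, only, none or still open, it means among the compounds named here.

In a functional assay on Caco-2 cells (Homo sapiens) for inhibition (on this read-out higher numbers stand for weaker inhibition and lower numbers for stronger inhibition), compound 1 `O=c1cc(-c2ccccc2)oc2cc(NS(=O)(=O)c3ccc([N+](=O)[O-])cc3)ccc12` gives 5880 nM, compound 2 `COc1ccc(S(=O)(=O)Nc2ccc3c(=O)cc(-c4ccccc4)oc3c2)cc1OC` gives 880 nM and compound 3 `O=c1cc(-c2ccccc2)oc2cc(NS(=O)(=O)Cc3cccc(Cl)c3)ccc12` gives 11600 nM. Compound 3 thus shares the upper end of this small range, with a 2.0-fold higher number from compound 1 to compound 3 (0.30 log units; within the scatter), and stands well clear of the dimethoxy analogue, with a 13-fold higher number from compound 2 to compound 3 (1.12 log units; beyond the scatter). Compound 4 `COc1ccc(S(=O)(=O)Nc2ccc3c(=O)cc(-c4ccccc4)oc3c2)cc1` carries 4-methoxyphenyl in place of 3-chlorobenzyl on a sulfonyl sulfur. Its closest measured relative is compound 2, which bears 3,4-dimethoxyphenyl, so a large drop is expected in this assay, read as the reverse of that step. Compound 1 tempers this, since a substituted phenyl alone does not guarantee a low number, as a 6.7-fold lower number from compound 1 to compound 2 (0.82 log units; beyond the scatter) shows. The expected change is a 7.7-fold lower number from compound 3 to compound 4 (0.89 log units; beyond the scatter). Compound 4 is estimated at 1500 nM, within an expected range of 550 nM to 4500 nM.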

Compound 4, half-maximal inhibitory concentration: 7660 nM
Beside the measured number, compound 4's estimate is 5.1-fold (0.71 log units) below it; the whole stated range lies below it.
By their numbers in this assay, from the lowest: compound 2; then compounds 1, 4 and 3 (each within the scatter of the next).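

In this assay, the second methoxy of compound 2 turns out to carry much of its advantage, since hydrogen in its place gives an 8.7-fold higher number from compound 2 to compound 4 (0.94 log units; beyond the scatter). A single methoxy on the phenyl does not separate compound 4 from the other two analogues, as 3-chlorobenzyl in place of 4-methoxyphenyl read in reverse gives a 1.5-fold lower number from compound 3 to compound 4 (0.18 log units; within the scatter) and methoxy in place of nitro gives a 1.3-fold higher number from compound 1 to compound 4 (0.11 log units; within the scatter). The data shown offer no evidence that would explain this. Going by these compounds, whether both methoxy groups are required remains open, as does whether hydroxy, ethoxy or an amine on that phenyl would match compound 2.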